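Aryl swaps on the shared core: lipophilicity working notes

The source may hold more compounds than are shown below. What is called first, only, known or untested is meant among the compounds shown, and "the series" means these compounds.

Measured so far in a physicochemical assay for lipophilicity; a higher number here means a more lipophilic compound, a lower number a more polar compound:
compound 1, `C[C@H]1CC[C@@H]2[C@@H](OC(=O)[C@]23CC(c2ccccc2Br)=NO3)[C@]2(C)C(=O)C=C[C@@]12O`: 2.22
compound 2, `C[C@H]1CC[C@@H]2[C@@H](OC(=O)[C@]23CC(c2ccccc2)=NO3)[C@]2(C)C(=O)C=C[C@@]12O`: 1.41
compound 3, `C[C@H]1CC[C@@H]2[C@@H](OC(=O)[C@]23CC(c2ccc(O)cc2)=NO3)[C@]2(C)C(=O)C=C[C@@]12O`: 0.932

Compound 1 stands highest of the three. Nearest to it is compound 2, with a number 0.81 log units lower from compound 1 to compound 2 (beyond the scatter); furthest is compound 3, with a number 1.29 log units lower from compound 1 to compound 3 (beyond the scatter). The remaining step, a number 0.48 log units lower from compound 2 to compound 3 (beyond the scatter), is the smaller of the two substituent removals or additions on the aromatic ring.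

Compound 4, `Cc1cccc(C2=NO[C@]3(C2)C(=O)O[C@@H]2[C@H]3CC[C@H](C)[C@]3(O)C=CC(=O)[C@@]23C)c1`, is not yet measured in this assay. Relative to compound 1 the change is 3-methylphenyl in place of 2-bromophenyl on a carbon with a double bond to nitrogen. Going by the values given here, the step that bears on it most directly is a number 0.81 log units lower from compound 1 to compound 2 (beyond the scatter), since it too removes the bromo from the ring; compound 4 then carries a methyl instead of nothing, and no measured step here covers a methyl. Taking compound 2 as the reference without bromo, a methyl is expected to bring the number part of the way back toward compound 1, so a drop from compound 1 smaller than the bromo removal, near the edge of the scatter, is expected.

For compound 4 the estimate in this assay is 1.9, expected between 1.6 and 2.2. This is expected to mean a number 0.32 log units lower from compound 1 to compound 4 (beyond the scatter).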

Compound 4, partition coefficient: 1.86
Beside the measured number, compound 4's estimate is 0.04 log units above it; the range from low to high includes it.
By their numbers in this assay, from the lowest: compound 3; then compound 2; then compound 4; then compound 1.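

In this assay, a methyl on the aromatic ring gives a number 0.45 log units higher from compound 2 to compound 4 (beyond the scatter), so the number at this position can rise with no bromine present. Exchanging 2-bromophenyl for 3-methylphenyl still leaves a number 0.36 log units lower from compound 1 to compound 4 (beyond the scatter), so these two groups, each of the same heavy-atom count, do not give the same number here, although the step changes both the substituent and its place on the ring and cannot separate the two. The step of a number 0.93 log units higher from compound 3 to compound 4 (beyond the scatter) joins two aryl groups that lie on opposite sides of the unsubstituted phenyl of compound 2, with the methyl-bearing compound 4 above it and the hydroxy-bearing compound 3 below it.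

From the compounds shown here alone, what underlies these steps remains open, as no supporting measurement is available. Also open, going by these compounds, is where an amine, a carboxylic acid or a longer chain on the aromatic ring would fall relative to these four compounds, and whether the methyl step would hold for such a group at another place on the ring.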